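From pyridin-3-yl to pyridin-4-yl in compound 3

The source may report more compounds than this note shows. Statements on the series, on what has been measured and on what is new or still open speak of the compounds shown alone.

In a functional assay (blood) for inhibition, with Homo sapiens as the target (a higher number here means a weaker inhibitor, a lower number a stronger inhibitor), compound 1 `CC(C)(C)Sc1c(CC(C)(C)C(=O)O)n(Cc2ccc(Cl)cc2)c2ccc(CCc3ccc4ccccc4n3)cc12` gives > 3000 nM as a limit, not a number. Compound 2 `CC(C)(C)Sc1c(CC(C)(C)C(=O)O)n(Cc2ccc(Cl)cc2)c2ccc(OCc3cc4ccccc4cn3)cc12` gives > 3000 nM as a limit too. Compound 3 `CC(C)(C)Sc1c(CC(C)(C)C(=O)O)n(Cc2ccc(Cl)cc2)c2ccc(OCc3cccnc3)cc12` stands in the same place, with > 3000 nM also a limit. For the measured compounds named here, the set so far offers only the limit of > 3000 nM in this assay, at which 3 of the 3 values shown sit, and no compound can be ranked.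

In compound 4 `CC(C)(C)Sc1c(CC(C)(C)C(=O)O)n(Cc2ccc(Cl)cc2)c2ccc(OCc3ccncc3)cc12` the change is pyridin-4-yl in place of pyridin-3-yl on a saturated chain carbon bound to an oxygen on an aromatic ring with pyridin-4-yl in place of pyridin-3-yl on a saturated chain carbon bound to an oxygen on an aromatic ring. The closest measured changes give no size: a step that the two limits leave unreadable from compound 2 to compound 3 is one, a step that the two limits leave unreadable from compound 1 to compound 3 is another, and a step that the two limits leave unreadable from compound 1 to compound 2 is a third. With no readable step to go on, no step beyond the scatter is expected in this assay in either direction. The expected step is a step that the limit leaves unreadable from compound 3 to compound 4 and it carries little certainty. Compound 4 is expected at 3500 nM within an estimated range of 1200 nM to 10000 nM. A limit rather than a number is also a likely outcome for compound 4.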

Compound 4, half-maximal inhibitory concentration: > 3000 nM
Compound 4: only a limit was reported; the forecaster's own chance of this, stated with the estimate: 75%; the middle value lies beyond the limit too.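

For the compounds shown here, no step among compound 1, compound 2, compound 3 and compound 4 can be read, since each gives only a limit: the limit of > 3000 nM in this assay, at which 4 of the 4 values shown sit. The compounds shown leave open how they rank against one another, and whether swapping pyridin-3-yl for pyridin-4-yl changes inhibition at all.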